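The compounds below may be only part of what the source reports. "The series", "measured", "known", "first", "only" and "open" are said of these compounds alone.

For the measured compounds named here, in an assay on isolated protein for inhibition of Fatty-acid amide hydrolase 1 (Rattus norvegicus) (on this read-out higher numbers stand for weaker inhibition and lower numbers for stronger inhibition), compound 1 `O=C(CCCCCCc1ccccc1)c1nc(Cl)co1` gives 4 nM, the second highest of the three numbers measured so far. Compound 2 `O=C(CCCCCCc1ccccc1)c1nc(-c2ccccn2)co1` gives 1.9 nM, and compound 3 `O=C(CCCCCCc1ccccc1)c1nc(-c2cccnc2)co1` gives 18 nM. Each of these two differs from compound 1 only on an aromatic carbon of the shared core, where the chloro is replaced: a 2.1-fold lower number from compound 1 to compound 2 (0.32 log units; beyond the scatter), whereas a 4.5-fold higher number from compound 1 to compound 3 (0.65 log units; beyond the scatter). Compound 4 `CNC(=O)c1coc(C(=O)CCCCCCc2ccccc2)n1` alters the same aromatic carbon in another way: methylcarbamoyl in place of chloro on an aromatic carbon. Going by the values given here, no measured step puts a methylcarbamoyl there, so the two replacements of chloro are the only guide, and they pull in opposite directions with modest size. A modest step is therefore expected, more likely toward a higher number, a 2.0-fold higher number from compound 1 to compound 4 (0.30 log units; within the scatter). For compound 4 the estimate is 8 nM, in a range from 2 nM to 40 nM.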

Compound 4, inhibition constant: 1.8 nM
The estimate for compound 4 lay 4.4-fold (0.65 log units) above the measured number; measured number below the stated range.
By their numbers in this assay, from the lowest: compounds 4 and 2 (each within the scatter of the next); then compound 1; then compound 3.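

Methylcarbamoyl, with four heavy atoms and a hydrogen-bond donor that chloro lacks, is accepted on this aromatic carbon: it gives a 2.2-fold lower number from compound 1 to compound 4 (0.35 log units; beyond the scatter) and also a 10-fold lower number from compound 3 to compound 4 (1.00 log units; beyond the scatter) on replacing pyridin-3-yl. With a 1.1-fold lower number from compound 2 to compound 4 (0.02 log units; within the scatter) there is no real difference from pyridin-2-yl, so among these compounds a ring on this carbon is not needed to reach the number of compound 2. Nothing available explains these differences.

As far as these compounds go, whether the amide hydrogen matters remains open. So does the outcome with a carboxylic acid, a methyl ester or an unsubstituted amide on this carbon.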